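Methoxy added to compound 2: expected binding

The source may report more compounds than this note shows. Statements on the series, on what has been measured and on what is new or still open speak of the compounds shown alone.

Compound 1 `O=C(CCCc1ccccc1)Nc1nc2ccsc2c(=O)s1` in an assay on CHO cells for displacement of a labelled ligand from adenosine receptor A3 (Homo sapiens), read by scintillation counting, with a stated time of 60 min (on this read-out higher numbers stand for weaker inhibition and lower numbers for stronger inhibition), gives only a limit, > 1000 nM. Among the measured compounds shown here, compound 2 `O=C(CCc1ccccc1)Nc1nc2ccccc2c(=O)s1` gives 390 nM in this assay, the one number in the set. The other value shown is a limit, (the limit of > 1000 nM in this assay, at which 1 of the 2 values shown sits). Compound 3 `COc1cccc(CCC(=O)Nc2nc3ccccc3c(=O)s2)c1` differs from compound 2 by methoxy in place of hydrogen on an aromatic carbon. Nothing measured here tests a substituent on that ring, so no step beyond the scatter is expected from compound 2 to compound 3 in this assay, namely a 1.0-fold higher number from compound 2 to compound 3 (0.01 log units; within the scatter). Compound 3 is estimated at 400 nM in this assay, within a range from 150 nM to 1100 nM.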

Compound 3, inhibition constant: 173 nM
Estimate against measurement, compound 3: 2.3-fold (0.36 log units) above; the measured number falls inside the stated range.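

In this assay, methoxy in place of hydrogen on the aromatic carbon meta to a large group gives a 2.3-fold lower number from compound 2 to compound 3 (0.35 log units; beyond the scatter), a modest step. Among the compounds shown here, this is the first reading of a substituent on that ring, and it shows that phenyl to 3-methoxyphenyl is tolerated here without loss of binding. Nothing measured here bears on the reason for the step.

Going by these compounds, whether the step is specific to methoxy remains open. An amine, a hydroxyl or a chlorine at the same place could read differently.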